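The source may report more compounds than this note shows. Statements on the series, on what has been measured and on what is new or still open speak of the compounds shown alone.

Measured so far:
- compound 1, `CCOC(=O)C1=C(Nc2ccc(OC)cc2)S/C(=C\c2ccc[nH]2)C1=O`: 27.6%
- compound 2, `CCOC(=O)C1=C(Nc2ccc(F)cc2)S/C(=C\c2ccc[nH]2)C1=O`: 61.5%

In a functional assay on JAR cells (Homo sapiens) for inhibition, read by MTT assay, with a stated time of 72 h, tested at 10 uM (on this read-out lower numbers stand for less inhibition and higher numbers for more inhibition at the one concentration tested (going by the name of the read-out)), compound 2 gives 61.5%, the higher of the two numbers shown, while compound 1 gives 27.6%. For the measured compounds named here, the one measured step, a number 33.9 percentage points higher from compound 1 to compound 2 (beyond the scatter), swaps one group for another on an aromatic carbon; it is the only comparison available.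

Compound 3, `CCOC(=O)C1=C(Nc2cccc(F)c2)S/C(=C\c2ccc[nH]2)C1=O`, is built from the same atoms as compound 2 but joined differently: 3-fluorophenyl in place of 4-fluorophenyl on an amine nitrogen. Going by the values given here, no measured step covers a change of this kind, where the fluorine stays and only the fluorophenyl attached to the amine nitrogen is exchanged. The step from compound 1 to compound 2 does not bear on it directly. With no guide, the expectation is that compound 3 stays close to compound 2, with an expected step of a number 6.5 percentage points lower from compound 2 to compound 3 (within the scatter), not beyond the scatter. Compound 3 is therefore estimated at 55%, with a range from 35% to 75%.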

Compound 3, a percentage reported as inhibition, at one concentration (the size of the read-out at that concentration, not a potency): 45.4%
The estimate for compound 3 lay 9.6 percentage points above the measured number, and the stated range covers the measured number.
By their numbers in this assay, from the lowest: compound 1; then compound 3; then compound 2.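

In this assay, the fluorine stays and only its place on the phenyl ring changes, yet 3-fluorophenyl in place of 4-fluorophenyl on the amine nitrogen gives a number 16.1 percentage points lower from compound 2 to compound 3 (beyond the scatter), so the number at this position depends on more than the presence of a fluorine. 3-Fluorophenyl in place of 4-methoxyphenyl gives a number 17.8 percentage points higher from compound 1 to compound 3 (beyond the scatter), which means that both fluorophenyl compounds shown stand above the methoxy compound, with 4-fluorophenyl the higher of the two. No measurement at hand explains either step.

Going by these compounds, it remains open whether chlorine, a methyl or a nitrile in place of the fluorine would give numbers like those of compound 2 or compound 3. Also open, on these data alone, is what a pyridine ring in place of the phenyl would do on this amine nitrogen.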